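Removing the indole amide: an untested analogue of compound 2

The source may report more compounds than this note shows. Statements on the series, on what has been measured and on what is new or still open speak of the compounds shown alone.

Compound 1 `CC[C@@H]1C(=O)N(C)c2cnc(Nc3ccc(S(=O)(=O)NC4CCCC4)cc3)nc2N1C1CCCC1` gives 688 nM in a functional assay on MCF7 cells (Homo sapiens) for antiproliferative activity, read by CCK-8 assay, with a stated time of 72 h; a lower number here means a stronger inhibitor of growth, a higher number a weaker inhibitor of growth.
Compound 2 `CC[C@@H]1C(=O)N(C)c2cnc(-n3ccc4cc(C(=O)NCC(C)C)ccc43)nc2N1C1CCCC1` gives 953 nM in this assay.
Compound 3 `CCC1C(=O)N(C)c2cnc(Nc3ccc(S(N)(=O)=O)cc3)nc2N1c1ccn(C)n1` gives 36600 nM in this assay.

Of the three numbers, compound 2 stands in the middle. Its value and that of compound 1 lie within the scatter of each other, so no order between the two can be read; compound 3, by contrast, gives a far higher number, a gap well beyond the scatter.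

Compound 4 `CC[C@@H]1C(=O)N(C)c2cnc(-n3ccc4ccccc43)nc2N1C1CCCC1` differs from compound 2 in one place (hydrogen in place of isobutylcarbamoyl on an aromatic carbon). For the measured compounds named here, the indole part of compound 2 is kept and only this group is removed.

Going by the values given here, no pair of measured compounds shows the effect of such a removal, so the expected step rests on general experience with loss of an amide substituent. A modest step toward a higher number is expected for this assay, possibly beyond the scatter but not large. Compound 4 is therefore estimated at 2000 nM, with a range from 600 nM to 7000 nM, which means an expected step of a 2.1-fold higher number from compound 2 to compound 4 (0.32 log units; beyond the scatter).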

Compound 4, concentration for 50% growth inhibition: 17200 nM
Compound 4: middle estimate off by 8.6-fold (0.93 log units), on the low side; measured number above the stated range.
By their numbers in this assay, from the lowest: compounds 1 and 2 (each within the scatter of the next); then compound 4; then compound 3.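

In this assay, for the compounds shown here, putting hydrogen in place of isobutylcarbamoyl on this aromatic carbon gives an 18-fold higher number from compound 2 to compound 4 (1.26 log units; beyond the scatter) and is the only step here that isolates a change in one place. It shows that this position is not indifferent to what it carries: on the shared core, the much lower number of compound 2 depends on the isobutylcarbamoyl group being present. No measurement at hand gives a reason for the size of this step.

What stays open is which part of the group carries the step, since the compounds shown do not separate the amide from its isobutyl chain. As far as these compounds go, a primary carboxamide, a carboxylic acid or a longer chain on the same carbon could tell these apart, and whether the step holds with other groups elsewhere on the core also remains unknown.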